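Swapping bromo for chloro: compound 2 to compound 4

The source may report more compounds than this note shows. Statements on the series, on what has been measured and on what is new or still open speak of the compounds shown alone.

Compound 1 `COc1cc(/C=C/C(=O)c2ccc(N)c(-c3ccc(F)cc3)c2)ccc1O`: 4300 nM
Compound 2 `O=C(/C=C/c1ccc(Br)cc1)c1cccc(-c2cccc(F)c2)c1`: 9920 nM
Compound 3 `COc1ccc(/C=C/C(=O)c2cccc(Br)c2)cc1`: "not determined" (no result reported)

Among the measured compounds shown here, in a functional assay on HepG2 cells (Homo sapiens) for cytotoxicity, read by sulforhodamine B assay, with a stated time of 48 h (on this read-out higher numbers stand for weaker inhibition and lower numbers for stronger inhibition), compound 2 gives 9920 nM, the higher of the only two numbers available. Compound 1 gives 4300 nM, and that gap lies beyond the usual scatter. Compound 4 `O=C(/C=C/c1ccc(Cl)cc1)c1cccc(-c2cccc(F)c2)c1` departs from compound 2 in one place: chloro in place of bromo on an aromatic carbon. For the measured compounds named here, no measured pair shows this change, so the expectation in this assay is no step beyond the scatter, in either direction. The expected 1.0-fold higher number from compound 2 to compound 4 (0.00 log units; within the scatter) is therefore small. For compound 4 the estimated value is 10000 nM, with an expected range of 5000 nM to 20000 nM.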

Compound 4, half-maximal inhibitory concentration: 10400 nM
The estimate for compound 4 lay 1.0-fold (0.02 log units) below the measured number, within the range that was stated.
By their numbers in this assay, from the lowest: compound 1; then compounds 2 and 4 (each within the scatter of the next).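

In this assay, among the compounds shown here, this is the first step measured at the para position of the 4-bromophenyl group, and it reads a 1.0-fold higher number from compound 2 to compound 4 (0.02 log units; within the scatter) so the two halogens cannot be told apart on this read-out. Within this one pair, chloro serves in place of bromo on the aromatic carbon with no change beyond the scatter. No evidence at hand bears on why this is so. As far as these compounds go, whether a group other than a halogen, such as a nitrile or a carboxylic acid, would be tolerated in that place remains open. So does whether the same swap behaves alike on the core of compound 1.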